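The compounds below may be only part of what the source reports. "The series", "measured", "known", "first", "only" and "open" are said of these compounds alone.

In a functional assay on HL-60 cells (Homo sapiens) for antiproliferative activity, read by MTT assay, with a stated time of 72 h (on this read-out higher numbers stand for weaker inhibition and lower numbers for stronger inhibition), compound 1 `COc1cc(-n2ncnc2-c2ccc(C)cc2)cc(OC)c1OC` gives 90 nM. Compound 2 `COc1cccc(-c2ncnn2-c2cc(OC)c(OC)c(OC)c2)c1` gives > 10000 nM, which is a limit and not a number. Compound 3 `COc1cc(-n2ncnc2-c2ccc(Cl)c(Cl)c2)cc(OC)c1OC` gives > 10000 nM, also a limit. This is the limit of > 10000 nM in this assay, at which 2 of the 3 values shown sit, so compound 2 offers no measured number to start from.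

Compound 4 `CCOc1cccc(-c2ncnn2-c2cc(OC)c(OC)c(OC)c2)c1` differs from compound 2 by methyl in place of hydrogen on a saturated chain carbon bound to an oxygen on an aromatic ring, which turns methoxy into ethoxy. Within the data shown here, no measured step tests this change directly. Among the measured compounds shown here, two steps bear on it indirectly, both replacing 4-methylphenyl: an at least 110-fold higher number from compound 1 to compound 2 (2.04 log units; beyond the scatter) with 3-methoxyphenyl, and an at least 110-fold higher number from compound 1 to compound 3 (2.04 log units; beyond the scatter) with 3,4-dichlorophenyl. Both are large, and both end at the limit. Among these compounds, only compound 1 gives a number.

A return to the potency of compound 1 is not expected in this assay, and the reading will most likely stay at the limit. The expected step is a number no higher from compound 2 to compound 4 (the limit leaves the size open), none beyond the scatter. For compound 4 the estimate is 10000 nM, with an expected range of 2000 nM to 30000 nM.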

Compound 4, half-maximal inhibitory concentration: > 10000 nM
Compound 4 was reported as a limit; the forecaster's own chance of this, stated with the estimate: 80%; the middle value lies on the limit itself.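

Compound 4 gives > 10000 nM, a limit and not a number. With compound 2 also at a limit, no step between compound 2 and compound 4 can be read in this assay: the limit of > 10000 nM in this assay, at which 3 of the 4 values shown sit.

From the compounds shown here alone, whether methoxy to ethoxy changes the reading at all remains open.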